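The source may hold more compounds than are shown below. What is called first, only, known or untested is meant among the compounds shown, and "the series" means these compounds.

Compound 1, `Nc1cc(N)c2nc(-c3ccccc3)c(NCc3ccc(Cl)c(Cl)c3)nc2c1`, carries a 3,4-dichlorophenyl group on the saturated chain carbon bound to a nitrogen on the aromatic ring, and in a functional assay on RXF 393 cells (Homo sapiens) for inhibition, read by sulforhodamine B assay, with a stated time of 48 h (a higher number here means a weaker inhibitor of growth, a lower number a stronger inhibitor of growth), compound 1 gives 17000 nM. Compound 2, `COc1ccc(CNc2nc3cc(N)cc(N)c3nc2-c2ccccc2)cc1OC`, has a 3,4-dimethoxyphenyl group in that place. In this assay compound 2 gives < 100000 nM, which is a limit of the assay and not a number. The step that the limit leaves unreadable from compound 1 to compound 2 therefore cannot be read, and where compound 2 stands on the numbers is known only as this limit, (the limit of < 100000 nM in this assay, at which 1 of the 2 values shown sits).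

Compound 3, `COc1cc(CNc2nc3cc(N)cc(N)c3nc2-c2ccccc2)cc(OC)c1OC`, is not yet measured. It differs from compound 2 by methoxy in place of hydrogen on an aromatic carbon. Among the compounds with values here, no measured step in this set bears on adding a methoxy group to that aromatic ring, and the single step that exists, from compound 1 to compound 2, has no readable size. The direction of any change from compound 2 to compound 3 is thus open, and a step no larger than the usual scatter is as plausible as any other.

With that caution, compound 3 is estimated at 40000 nM in this assay, in a range from 10000 nM to 100000 nM, which means an expected step that the limit leaves unreadable from compound 2 to compound 3.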

Compound 3, concentration for total growth inhibition: 20000 nM
Compound 3: middle estimate off by 2.0-fold (0.30 log units), on the high side; the measured number falls inside the stated range.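

Compound 2 is known only as a limit, so the step from it to compound 3 cannot be read, even with a number now in hand for compound 3: the limit of < 100000 nM in this assay, at which 1 of the 3 values shown sits.

The compounds shown leave open whether methoxy in place of hydrogen on that aromatic carbon changes the result in this assay at all, and in which direction.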